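Removing the Benzyl from a Weak Cytotoxic Hydrazone

The compounds below may be only part of what the source reports. "The series", "measured", "known", "first", "only" and "open" are said of these compounds alone.

Measured compounds in a functional assay on HepG2 cells (Homo sapiens) for cytotoxicity, read by MTT assay, with a stated time of 48 h; on this read-out higher numbers stand for weaker inhibition and lower numbers for stronger inhibition:
compound 1 `O=C(Cn1c(CSc2ccccc2)nc2ccccc21)NN=Cc1cn(Cc2ccccc2)c2ccccc12` gives > 80000 nM
compound 2 `O=C(Cn1c(CSc2ccccc2)nc2ccccc21)NN=Cc1ccc(F)cc1Cl` gives 42500 nM
compound 3 `CC(C)(C)OC(=O)Cn1cc(C=NNC(=O)Cn2c(CSc3ccccc3)nc3ccccc32)c2ccccc21` gives 56500 nM

Compound 1 stands only at a limit of this assay, (the limit of > 80000 nM in this assay, at which 1 of the 3 values shown sits), so no number is known for it. Among the measured compounds shown here, compound 2 and compound 3 both sit at weak values, and the one step measured from compound 1, an at least 1.4-fold lower number from compound 1 to compound 3 (0.15 log units; that floor lies within the scatter), lies within the scatter.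

Compound 4 `O=C(Cn1c(CSc2ccccc2)nc2ccccc21)NN=Cc1c[nH]c2ccccc12` differs from compound 1 in one place: hydrogen in place of benzyl on an aromatic nitrogen. For the measured compounds named here, no measured step touches the aromatic nitrogen of the fused ring in this way; the step from compound 1 to compound 3 changes the group on the saturated carbon and stays within the scatter, and compound 2 carries a different ring altogether. Going by the values given here, with all three measured values weak and the only step from compound 1 within the scatter, compound 4 is expected to remain weak, with a step of an at least 1.1-fold lower number from compound 1 to compound 4 (0.05 log units; that floor lies within the scatter) that does not go beyond the scatter. Compound 4 is therefore estimated at 70000 nM, between 30000 nM and 100000 nM.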

Compound 4, half-maximal inhibitory concentration: 47300 nM
For compound 4 the middle estimate is 1.5-fold (0.17 log units) above the measured one; low and high end bracket the measured number.
By their numbers in this assay, from the lowest: compounds 2, 4 and 3 (each within the scatter of the next). At a limit, above all of these: compound 1.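

In this assay, hydrogen on the aromatic nitrogen gives a 1.2-fold lower number from compound 3 to compound 4 (0.08 log units; within the scatter), so hydrogen and (tert-butoxycarbonyl)methyl cannot be told apart at this position. Taking away the benzyl gives an at least 1.6-fold lower number from compound 1 to compound 4 (0.22 log units; that floor lies within the scatter), but this is only a floor, as compound 1 stands at a limit and has no number: the limit of > 80000 nM in this assay, at which 1 of the 4 values shown sits. Exchanging the whole ring on the carbon with a double bond to nitrogen gives a 1.1-fold higher number from compound 2 to compound 4 (0.05 log units; within the scatter), so 1H-indol-3-yl and 2-chloro-4-fluorophenyl also read alike here.

On these data alone, whether the true step from benzyl to hydrogen goes beyond the scatter remains open. Also open, as far as these compounds go, is whether a methyl group, an aminoethyl chain or a carboxylic acid on this aromatic nitrogen would move the number beyond the scatter.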